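Working notes: methyl to iodoacetamide on the shared core

This account rests on a few compounds, and the source may have more. Where it says the series, first, only, none or still open, it means among the compounds named here.

Two compounds of this series carry numbers in an ADME assay on the whole organism (thoracic aorta) with Rattus norvegicus as the target; a higher number here means a larger maximal response, a lower number a smaller maximal response. Compound 1 `S=C=Nc1ccc(CCC2=NCCN2)cc1` gives 102%. Compound 2 `Cc1ccc(CC2=NCCN2)cc1` gives 5%, the lowest of the two values, with compound 1 standing higher by a margin beyond the scatter. The two compounds differ in more than one place, so their gap is taken only as what the two values show.

Compound 3 `O=C(CI)Nc1ccc(CC2=NCCN2)cc1` has not been measured. Relative to compound 2 the change is ((iodomethyl)carbonyl)amino in place of methyl on an aromatic carbon.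

Among the measured compounds shown here, no step between measured compounds exists for this change. The value of compound 2 in this assay, 5%, leaves almost the whole range open upward. Given that compound 1 reaches 102% with a different group on the same position, a rise beyond the scatter is expected from compound 2 to compound 3, but its size is uncertain, so the estimated step is a number 40 percentage points higher from compound 2 to compound 3 (beyond the scatter). For compound 3 the expected value is 45%, between 5% and 95%.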

Compound 3, largest response reached (Emax), in percent of the reference or control that the assay uses: 13%
Beside the measured number, compound 3's estimate is 32 percentage points above it; the measured number falls inside the stated range.
By their numbers in this assay, from the lowest: compounds 2 and 3 (each within the scatter of the next); then compound 1.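

In this assay, the exchange of methyl for ((iodomethyl)carbonyl)amino on an aromatic carbon gives a number 8 percentage points higher from compound 2 to compound 3 (within the scatter). Among the compounds shown here, this is the first single-place step at this position, and it shows that this exchange alone, with 5 heavy atoms entering for 1, does not separate the two compounds in this assay. No measurement at hand bears on the reason for this result.

Compound 1 differs from both compounds in more than one place, so its value of 102% cannot be assigned to any single difference. Still open, going by these compounds, is whether an amine or a carboxylic acid on the same aromatic carbon, or a longer chain carrying ((iodomethyl)carbonyl)amino, would stand apart from compound 2 by more than the scatter.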